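This account rests on a few compounds, and the source may have more. Where it says the series, first, only, none or still open, it means among the compounds named here.

In a functional assay on L6 cells (Rattus norvegicus) for cytotoxicity (a lower number here means a stronger inhibitor, a higher number a weaker inhibitor), compound 1 `O=c1ccn([C@H]2C[C@H](O)[C@@H](CNC(c3ccccc3)(c3ccccc3)c3ccccc3)O2)c(=O)[nH]1` gives 44000 nM and compound 2 `O=c1ccn(CCCOC(c2ccccc2)(c2ccccc2)c2ccccc2)c(=O)[nH]1` gives 34000 nM, so these two lie within the usual scatter of each other. For compound 3 `O=C(OCCCn1ccc(=O)[nH]c1=O)c1ccccc1` the entry is "not determined" (no result reported). Compound 4 `O=c1ccn(CCCCCCOC(c2ccccc2)(c2ccccc2)c2ccccc2)c(=O)[nH]1` differs from compound 2 in one place: a group of 11 heavy atoms (7 carbon, 2 nitrogen, 2 oxygen; one six-membered aromatic ring with 2 hetero atoms) in place of a group of 8 heavy atoms (4 carbon, 2 nitrogen, 2 oxygen; one six-membered aromatic ring with 2 hetero atoms), on a saturated chain carbon, three bonds along the chain from an oxygen on a saturated carbon. For the measured compounds named here, no measured pair shows what a change of this kind does, so this forecast is uncertain. Only a small move toward a lower number is expected in this assay, little more than the scatter. The estimated change is a 1.7-fold lower number from compound 2 to compound 4 (0.23 log units; within the scatter). For compound 4 the expected value is 20000 nM, with an estimated range of 7000 nM to 60000 nM.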

Compound 4, half-maximal inhibitory concentration: 44000 nM
For compound 4 the middle estimate is 2.2-fold (0.34 log units) below the measured one, and the stated range covers the measured number.
By their numbers in this assay, from the lowest: compounds 2, 1 and 4 (each within the scatter of the next).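

In this assay, for the compounds shown here, the one step at this place reads a 1.3-fold higher number from compound 2 to compound 4 (0.11 log units; within the scatter), so the group of 11 heavy atoms and the group of 8 heavy atoms, on a saturated chain carbon, cannot be told apart in this measurement. No measured evidence bears on this result. The compounds shown leave open whether a longer chain would also stay within the scatter of compound 2. They also leave open what an amine in place of the oxygen would do.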